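Formyl for bromo on a fused bicyclic core: cytotoxicity expectations

The source may hold more compounds than are shown below. What is called first, only, known or untested is meant among the compounds shown, and "the series" means these compounds.

Compound 1 `Clc1ccc(Cc2nn3c(Br)c(-c4ccccc4)nc3s2)cc1`: > 250000 nM
Compound 2 `O=c1oc2ccccc2cc1-c1nc2sc(Cc3ccc(Cl)cc3)nn2c1Br`: 4500 nM
Compound 3 `O=Cc1c(-c2ccccc2)nc2sc(Cc3ccc(Cl)cc3)nn12`: 45000 nM

Of the compounds shown here, three have been tested in a functional assay on HeLa cells (Homo sapiens) for cytotoxicity, with a stated time of 72 h; a lower number here means a stronger inhibitor, a higher number a weaker inhibitor. For compound 1 the value > 250000 nM is a limit of the assay, not a number, as the evidence the limit of > 250000 nM in this assay, at which 1 of the 3 values shown sits, records. Compound 3 gives 45000 nM, and the change formyl in place of bromo on an aromatic carbon brings an at least 5.5-fold lower number from compound 1 to compound 3 (0.74 log units; beyond the scatter). Compound 2 gives 4500 nM, the lowest of the two numbers measured, and the difference between its core and that of compound 1 is not broken down here.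

Compound 4 `O=Cc1c(-c2cc3ccccc3oc2=O)nc2sc(Cc3ccc(Cl)cc3)nn12` is not yet measured. It relates to compound 2 through (formyl in place of bromo on an aromatic carbon), the same kind of change as from compound 1 to compound 3, though the place lines differ: in one the altered carbon is next to the ring atom that bears a phenyl group (6 heavy atoms), in the other next to the ring atom that bears a large group. Because the change from compound 1 to compound 3 gave an at least 5.5-fold lower number from compound 1 to compound 3 (0.74 log units; beyond the scatter), a step of similar direction is expected, a 4.5-fold lower number from compound 2 to compound 4 (0.65 log units; beyond the scatter). Compound 4 is accordingly estimated at 1000 nM, between 300 nM and 4000 nM.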

Compound 4, half-maximal inhibitory concentration: 900 nM
Compound 4: the middle estimate sits 1.1-fold (0.05 log units) above what was measured; measured number inside the range.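

In this assay the change of formyl in place of bromo on an aromatic carbon gives a 5.0-fold lower number from compound 2 to compound 4 (0.70 log units; beyond the scatter) on the core that carries the large group, the same direction as on the core of compound 1. Set side by side, the two cases read as follows: the same change on two cores in this assay, an at least 5.5-fold lower number (0.74 log units; beyond the scatter) from compound 1 to compound 3 and a 5.0-fold lower number (0.70 log units; beyond the scatter) from compound 2 to compound 4; the limit leaves it open whether they differ. This shows that the direction of the change held on these two cores, but it does not show that the size of the step carries over exactly, and two cores make no general rule for the series.

The compounds shown leave open what other groups on the same aromatic carbon would do, for instance a carboxylic acid, an amine or a longer chain in place of the formyl. They also leave open whether formyl in place of bromo would give a step in the same direction on a core bearing something other than the phenyl group of compound 3 or the large group of compound 4.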